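A few compounds are considered here, and "the series" means these few. Any claim that something is new, unique, unknown or untested is made for them only; others in the source may bear on it.

In a functional assay on LOX IMVI cells (Homo sapiens) for cytotoxicity, read by MTT assay, with a stated time of 24 h (on this read-out lower numbers stand for stronger inhibition and higher numbers for weaker inhibition), compound 1 (`O=S(=O)(NCCCNc1nccc(-c2[nH]c(-c3ccccc3)nc2-c2ccc(Cl)c(O)c2)n1)c1ccccc1`) gives 2630 nM, compound 2 (`O=S(=O)(NCCCNc1nccc(-c2[nH]c(-c3ccccc3)nc2-c2ccc(Cl)c(O)c2)n1)c1ccc(Cl)cc1`) gives 61300 nM and compound 3 (`O=S(=O)(NCCCNc1nccc(-c2[nH]c(-c3ccccc3)nc2-c2ccc(Cl)c(O)c2)n1)c1ccc(F)cc1`) gives 2300 nM. Compound 3 thus shares the low end of this small range. The numbers show a 1.1-fold lower number from compound 1 to compound 3 (0.06 log units; within the scatter), and also a 27-fold lower number from compound 2 to compound 3 (1.43 log units; beyond the scatter). Compound 4 (`Cc1ccc(S(=O)(=O)NCCCNc2nccc(-c3[nH]c(-c4ccccc4)nc3-c3ccc(Cl)c(O)c3)n2)cc1`) carries a single change relative to compound 3: methyl in place of fluoro on an aromatic carbon. Two measured steps at this place bear on it: a 1.1-fold lower number from compound 1 to compound 3 (0.06 log units; within the scatter), and a 23-fold higher number from compound 1 to compound 2 (1.37 log units; beyond the scatter). Going by the values given here, no methyl example has been measured, so a moderate rise is expected, smaller than the chloro step, with wide uncertainty. The expected change is a 3.0-fold higher number from compound 3 to compound 4 (0.48 log units; beyond the scatter). Compound 4 is estimated at 7000 nM, within a range of 1500 nM to 45000 nM.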

Compound 4, half-maximal inhibitory concentration: 6020 nM
Beside the measured number, compound 4's estimate is 1.2-fold (0.07 log units) above it, within the range that was stated.
By their numbers in this assay, from the lowest: compounds 3 and 1 (each within the scatter of the next); then compound 4; then compound 2.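

Methyl at this position sits apart from both earlier substituents, with a 2.3-fold higher number from compound 1 to compound 4 (0.36 log units; beyond the scatter) and a 2.6-fold higher number from compound 3 to compound 4 (0.42 log units; beyond the scatter) both modest, while a 10-fold lower number from compound 2 to compound 4 (1.01 log units; beyond the scatter) is large. A change at this place on the ring therefore need be neither as silent as fluoro nor as steep as chloro. Nothing available explains this order. On these data alone, whether a methoxy group, an amine or a carboxylic acid at this place would fall within the same span stays open, as does whether the order of these groups holds in other cell lines.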